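The source may report more compounds than this note shows. Statements on the series, on what has been measured and on what is new or still open speak of the compounds shown alone.

Measured compounds:
compound 1 `O=C1c2ccccc2NS(=O)(=O)N1COCCO` — > 50 ug/mL
compound 2 `O=C1c2ccccc2N(COCc2ccccc2)S(=O)(=O)N1Cc1ccccc1` — > 50 ug/mL

In a functional assay on HEL cells (Homo sapiens) for cytotoxicity (a lower number here means that less compound is tolerated, a higher number that more compound is tolerated), compound 1 reaches only a limit, > 50 ug/mL, and no number. Compound 2 likewise gives only a limit in this assay, > 50 ug/mL. Both results therefore sit at the same place: the limit of > 50 ug/mL in this assay, at which 2 of the 2 values shown sit. Within the data shown here, nothing in these two values sets compound 2 apart from compound 1, and no step between measured compounds can be read from them.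

Compound 3 `O=C(OCCOCN1c2ccccc2C(=O)N(Cc2ccccc2)S1(=O)=O)c1ccccc1` is not yet measured. It differs from compound 2 in one place: (benzoyloxy)methyl in place of phenyl on a saturated chain carbon bound to an oxygen on a saturated carbon. The shared core and its benzyl substituent are kept; only the group on the saturated chain carbon bound to an oxygen on a saturated carbon changes.

Among the measured compounds shown here, with both measured values sitting at the limit, there is no measured step from which to gauge this change. For compound 3 the expected step in this assay is a number no higher from compound 2 to compound 3 (the limit leaves the size open), which is taken to mean no change beyond the scatter. The estimate for compound 3 in this assay is 50 ug/mL, with a range from 20 ug/mL to 100 ug/mL, and the result is expected to be a limit again rather than a number.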

Compound 3, minimum cytotoxic concentration: 50 ug/mL
For compound 3 middle estimate and measured number coincide at the digits printed, and the stated range covers the measured number.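

In this assay, compound 3 gives a true number, 50 ug/mL, the first of the three compounds shown to do so. Placing (benzoyloxy)methyl in place of phenyl on a saturated chain carbon bound to an oxygen on a saturated carbon, which can also be read as 2-(benzoyloxy)ethyl in place of benzyl, gives a number no higher from compound 2 to compound 3 (the limit leaves the size open). This shows that a number can be obtained from this assay with a change at this one place, but the size of the step stays unknown because its starting point is only a limit: the limit of > 50 ug/mL in this assay, at which 2 of the 3 values shown sit.

The compounds shown leave open how far compound 3 truly lies from compound 2, and so whether this change affects the tolerated concentration at all. They also leave open how this assay would read with an amine, a carboxylic acid or a longer chain in place of (benzoyloxy)methyl at this place, and whether any such group would give a number or another limit.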